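Amine ring swap in a poorly soluble anilide series

This account rests on a few compounds, and the source may have more. Where it says the series, first, only, none or still open, it means among the compounds named here.

Of the compounds shown here, two have been measured so far. In a physicochemical assay for solubility, measured as kinetic solubility (a higher number here means a more soluble compound, a lower number a less soluble compound), compound 2 `CC(=O)Nc1cc(-c2ccc(N(C)C(=O)c3c(F)cccc3Cl)c(N3CCCCC3)c2)n(C(C)C)n1` gives 1.3 ug/mL, nominally the higher of the two numbers, while compound 1 `CC(=O)Nc1cc(-c2ccc(N(C)C(=O)c3c(F)cccc3Cl)c(N3CC4CC4C3)c2)n(CC(C)(C)C)n1` gives 0.8 ug/mL; the gap lies within the scatter, so both stand level at low solubility. Compound 3 `CC(=O)Nc1cc(-c2ccc(N(C)C(=O)c3c(F)cccc3Cl)c(N3CC4CC4C3)c2)n(C(C)C)n1` carries the change (a group of 6 heavy atoms (5 carbon, 1 nitrogen; one three-membered non-aromatic ring of carbon only, one five-membered non-aromatic ring with 1 hetero atom) in place of a group of 6 heavy atoms (5 carbon, 1 nitrogen; one six-membered non-aromatic ring with 1 hetero atom), on an aromatic carbon). Among the compounds with values here, no step between measured compounds isolates this change, so its size is unknown. The step of a 1.3-fold lower number from compound 2 to compound 3 (0.11 log units; within the scatter) is expected to stay within the scatter, in no settled direction. Compound 3 is estimated at 1 ug/mL, within 0.4 ug/mL to 2.5 ug/mL.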

Compound 3, solubility: 2.1 ug/mL
The estimate for compound 3 lay 2.1-fold (0.32 log units) below the measured number; low and high end bracket the measured number.
By their numbers in this assay, from the lowest: compounds 1, 2 and 3 (each within the scatter of the next, the first and the last beyond it).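

In this assay, within the data shown here, the fused bicyclic amine in place of piperidin-1-yl gives a 1.6-fold higher number from compound 2 to compound 3 (0.21 log units; within the scatter), so this ring swap on the aromatic carbon shows no step that can be separated from the scatter. Isopropyl in place of neopentyl on the aromatic nitrogen gives a 2.6-fold higher number from compound 1 to compound 3 (0.42 log units; beyond the scatter), the first single-place step in the series beyond the scatter. Nothing at hand bears on the origin of either step. Open, on these data alone, is how a morpholine or a piperazine on that aromatic carbon would read, and whether a cyclopropyl on the aromatic nitrogen would follow isopropyl.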